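This account rests on a few compounds, and the source may have more. Where it says the series, first, only, none or still open, it means among the compounds named here.

Compound 1 `COc1ccccc1-c1cnc(C(=O)CCCCCCc2ccccc2)o1` gives 400 nM in an assay (Rattus norvegicus) for inhibition of Fatty-acid amide hydrolase 1 (Homo sapiens); on this read-out higher numbers stand for weaker inhibition and lower numbers for stronger inhibition. Among the compounds with values here, compound 2 `Nc1cccc(-c2cnc(C(=O)CCCCCCc3ccccc3)o2)c1` gives 19 nM in this assay, and the single change between them brought a 21-fold lower number from compound 1 to compound 2 (1.32 log units; beyond the scatter). Of the two measured numbers, compound 1 thus holds the highest. Compound 3 `O=C(O)c1ccc(-c2cnc(C(=O)CCCCCCc3ccccc3)o2)cc1` differs from compound 1 by 4-carboxyphenyl in place of 2-methoxyphenyl on an aromatic carbon. Within the data shown here, only one measured step bears on this: removing the 2-methoxyphenyl group in compound 2 gave a large drop, so for compound 3 a lower number is expected, though 4-carboxyphenyl is untested, giving an estimated 3.3-fold lower number from compound 1 to compound 3 (0.52 log units; beyond the scatter). Compound 3 is therefore expected near 120 nM, between 25 nM and 600 nM.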

Compound 3, inhibition constant: 60 nM
Compound 3: middle estimate off by 2.0-fold (0.30 log units), on the high side; the range from low to high includes it.
By their numbers in this assay, from the lowest: compound 2; then compound 3; then compound 1.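

A second replacement of the 2-methoxyphenyl group also lowers the number in this assay (a 6.7-fold lower number from compound 1 to compound 3 (0.82 log units; beyond the scatter)), so the gain at this position is not confined to the 3-aminophenyl group. The size of the gain depends on the group that enters, with 4-carboxyphenyl falling short of 3-aminophenyl (a 3.2-fold higher number from compound 2 to compound 3 (0.50 log units; beyond the scatter)). Nothing available explains this difference. Still open, going by these compounds, is how a plain phenyl group would compare, and whether the amine and the carboxylic acid would hold their numbers on another carbon of the phenyl ring.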